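Alpha-branched ester side chains on a shared bisindolylmaleimide core

The compounds below may be only part of what the source reports. "The series", "measured", "known", "first", "only" and "open" are said of these compounds alone.

Compound 1, `COC(=O)[C@@H](CC(C)C)NC(=O)Cn1cc(C2=C(c3c[nH]c4ccccc34)C(=O)N(C)C2=O)c2ccccc21`: in a functional assay on Bel-7402 cells (Homo sapiens) for cytotoxicity, read by MTT assay, with a stated time of 24 h (on this read-out lower numbers stand for stronger inhibition and higher numbers for weaker inhibition), compound 1 gives 42400 nM.
Compound 2, `CC[C@H](C)[C@@H](NC(=O)Cn1cc(C2=C(c3c[nH]c4ccccc34)C(=O)N(C)C2=O)c2ccccc21)C(=O)OC`: in this assay compound 2 gives only a limit, > 100000 nM.

For the measured compounds named here, compound 1 holds the only numerical value in this assay; the other result in the set is a limit. Going by the values given here, the one measured step, an at least 2.3-fold higher number from compound 1 to compound 2 (0.37 log units; beyond the scatter), moves from a number to the limit described by the limit of > 100000 nM in this assay, at which 1 of the 2 values shown sits, so its true size is not known beyond its lower bound.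

Compound 3, `COC(=O)[C@H](NC(=O)Cn1cc(C2=C(c3c[nH]c4ccccc34)C(=O)N(C)C2=O)c2ccccc21)C(C)C`, is obtained from compound 1 by the change (isopropyl in place of isobutyl on a saturated chain carbon bound to an amide-type nitrogen and a carbonyl carbon). The step to compound 2 is the only one that bears on it, since both replace isobutyl with a group branched at the carbon attached to the saturated chain carbon bound to an amide-type nitrogen and a carbonyl carbon. On that single precedent, compound 3 is expected to give a higher number in this assay than compound 1, with the step of a 1.8-fold higher number from compound 1 to compound 3 (0.25 log units; within the scatter) estimated as at least modest, and with a real chance that only a limit is returned. The estimate for compound 3 in this assay is 75000 nM, ranging from 35000 nM to 160000 nM.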

Compound 3, half-maximal inhibitory concentration: 4010 nM
Compound 3: the middle estimate sits 19-fold (1.27 log units) above what was measured; the measured number lies below the stated range.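

In this assay, the effect of a change at this position, on a saturated chain carbon bound to an amide-type nitrogen and a carbonyl carbon, depends on the exact group that enters: isopropyl in place of isobutyl gives an 11-fold lower number from compound 1 to compound 3 (1.02 log units; beyond the scatter), whereas sec-butyl in place of isobutyl gave an at least 2.3-fold higher number from compound 1 to compound 2 (0.37 log units; beyond the scatter). The two branched groups themselves part widely, with hydrogen in place of methyl, three bonds along the chain from an amide-type nitrogen and a carbonyl carbon, giving an at least 24-fold lower number from compound 2 to compound 3 (1.39 log units; beyond the scatter), and the size of this step is only a lower bound because one of its ends is a limit: the limit of > 100000 nM in this assay, at which 1 of the 3 values shown sits. Branching at the carbon attached to the chain carbon therefore does not by itself raise the number, since compound 2 fits such a rule and compound 3 goes against it.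

From the compounds shown here alone, it remains open whether a shorter unbranched chain such as ethyl or methyl, or a ring-bearing group such as benzyl, would follow compound 3 or compound 2 at this position. Going by these compounds, it is also open whether the gain seen with isopropyl would survive a carboxylic acid or an amide in place of the methyl ester.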